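Cyano for Methyl: Expected Half-Life of Compound 4

The compounds below may be only part of what the source reports. "The series", "measured", "known", "first", "only" and "open" are said of these compounds alone.

Measured compounds:
compound 1 `CC1(C)Oc2ccc(C#N)cc2[C@@H](N=C(NC#N)c2cccnc2)[C@@H]1O`: 0.08 h
compound 2 `COCC1(C)Oc2ccc(C#N)cc2[C@@H](N=C(NC#N)c2cccnc2)[C@@H]1O`: 0.04 h
compound 3 `CCn1nc(N[C@@H]2c3cc(C#N)ccc3OC(COC)(COC)[C@H]2O)ccc1=O`: 0.0867 h

Of the compounds shown here, three share a core and have been measured in an ADME assay on the whole organism (blood) for pharmacokinetics, with Canis familiaris (Canis lupus familiaris) as the target; a higher number here means that the compound lasts longer, a lower number that the compound disappears faster. Compound 3 has the highest of the three numbers, but its gap to compound 1 lies within the scatter, so the two cannot be ordered; only compound 2 stands clearly apart, with a number beyond the scatter below that of compound 3.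

Compound 4 `COCC1(COC)Oc2ccc(C#N)cc2[C@@H](Nc2ccc(=O)n(CC#N)n2)[C@@H]1O` is the next compound in this series. It differs from compound 3 in one place: cyano in place of methyl on a saturated chain carbon bound to an aromatic nitrogen

Going by the values given here, only one measured step is known, and it concerns a different place in the molecule: a methoxy in place of hydrogen on a saturated chain carbon bound to a saturated ring carbon, which gave a 2.0-fold lower number from compound 1 to compound 2 (0.30 log units; within the scatter). Among the compounds with values here, no measured step touches the group on the aromatic nitrogen, so nothing here points to a shift in either direction. Within the data shown here, with the single known step within the scatter, compound 4 is expected to give a step no larger than the scatter, written as a 1.1-fold lower number from compound 3 to compound 4 (0.03 log units; within the scatter).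

Compound 4 is therefore estimated at 0.08 h, with a range from 0.04 h to 0.16 h.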

Compound 4, half-life: 0.0517 h
Beside the measured number, compound 4's estimate is 1.5-fold (0.19 log units) above it; the range from low to high includes it.
By their numbers in this assay, from the lowest: compounds 2, 4, 1 and 3 (each within the scatter of the next, the first and the last beyond it).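

Cyano in place of methyl on a saturated chain carbon bound to an aromatic nitrogen, which also reads as ethyl to cyanomethyl, gives the first measured step at this place in this assay, with a 1.7-fold lower number from compound 3 to compound 4 (0.22 log units; within the scatter) as the result. Going by these compounds alone, the earlier compounds could not speak to this group, since their only step lay elsewhere in the molecule; this step now shows that the change, like that earlier one, cannot be told apart from the differences seen between repeated measurements, so it gives no firm sign that this exchange alters the half-life in dogs. Nothing in the available data offers an explanation for the size or direction of the step.

From the compounds shown here alone, a single exchange at this place says little about the position as a whole, and it remains open whether a longer chain, an amine or a carboxylic acid on the same chain carbon would give a step beyond the scatter. Going by these compounds, it is also open whether cyano in place of methyl would give a similar step on the other compounds, which carry different groups on the shared core.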